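From pyridin-2-yl to pyrazin-2-yl on the shared core

A few compounds are considered here, and "the series" means these few. Any claim that something is new, unique, unknown or untested is made for them only; others in the source may bear on it.

- compound 1 `CCC(C)(C)c1ccc(OCCCCN2CCN(c3cnccn3)CC2)cc1` with 9.56 nM measured
- compound 2 `CC(C)(C)c1ccc(OCCCCN2CCN(c3ccccn3)CC2)cc1` with 11.9 nM measured

In a functional assay on L5178Y cells (Mus musculus) for antiproliferative activity, read by MTT assay (on this read-out higher numbers stand for weaker inhibition and lower numbers for stronger inhibition), compound 2 gives 11.9 nM and has compound 1 as its nearest neighbour, the two numbers lying within the usual scatter of each other. Compound 3 `CC(C)(C)c1ccc(OCCCCN2CCN(c3cnccn3)CC2)cc1` keeps the core of compound 2 and carries pyrazin-2-yl in place of pyridin-2-yl on an amine nitrogen in a ring. For the measured compounds named here, no measured pair shows this change on its own. Going by the values given here, the only guide is compound 1, which also carries pyrazin-2-yl and gives 9.56 nM in this assay as the closest reference. A step beyond the scatter is therefore not expected in either direction, and the estimated size is a 1.1-fold lower number from compound 2 to compound 3 (0.05 log units; within the scatter) at most within that scatter. The estimated value for compound 3 is 10.5 nM with an expected range from 5 nM to 22 nM.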

Compound 3, half-maximal inhibitory concentration: 9.86 nM
Beside the measured number, compound 3's estimate is 1.1-fold (0.03 log units) above it; low and high end bracket the measured number.
By their numbers in this assay, from the lowest: compounds 1, 3 and 2 (each within the scatter of the next).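

For the compounds shown here, for the first time, the exchange of pyridin-2-yl for pyrazin-2-yl on an amine nitrogen in a ring stands alone in a matched pair, and in this assay the two numbers stay within the scatter (a 1.2-fold lower number from compound 2 to compound 3 (0.08 log units; within the scatter)), although pyrazin-2-yl carries 2 hetero atoms where pyridin-2-yl carries 1. With pyrazin-2-yl held constant, hydrogen in place of methyl on a saturated chain carbon, two bonds along the chain from an aromatic carbon, also stays within the scatter (a 1.0-fold higher number from compound 1 to compound 3 (0.01 log units; within the scatter)). No measurement at hand gives a reason for either result.

From the compounds shown here alone, whether a phenyl, a pyrimidin-2-yl or an acetyl group on the same amine nitrogen would keep the number in this range remains open. So does the effect of a shorter or longer chain in place of the one shared by these compounds.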